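The source may hold more compounds than are shown below. What is called first, only, known or untested is meant among the compounds shown, and "the series" means these compounds.

Measured so far:
- compound 1 `O=C(C1CCC(F)(F)CC1)N1CC(c2nc(-c3cccc(F)c3)no2)C1`: in an assay on HEK293 cells for negative allosteric modulation of metabotropic glutamate receptor 5 (Homo sapiens), read by FLIPR (on this read-out lower numbers stand for stronger inhibition and higher numbers for weaker inhibition), compound 1 gives only a limit, > 10000 nM.
- compound 2 `O=C(c1ccc(F)cc1)N1CC(c2nc(-c3cccc(Cl)c3)no2)C1`: compound 2 gives 4000 nM in this assay.
- compound 3 `O=C(C1CCC1)N1CC(c2nc(-c3cccc(Cl)c3)no2)C1`: compound 3 gives 1500 nM.

Compound 3 holds the lowest of the two numbers shown; its nearest neighbour is compound 2, and the only measured step, a 2.7-fold lower number from compound 2 to compound 3 (0.43 log units; beyond the scatter), went toward the cyclobutyl amide. Compound 4 `O=C(C1CCC(F)(F)CC1)N1CC(c2nc(-c3cccc(Cl)c3)no2)C1` differs from compound 3 by 4,4-difluorocyclohexyl in place of cyclobutyl on a carbonyl carbon. Among the compounds with values here, no measured step covers this change. Within the data shown here, the one value shown for a 4,4-difluorocyclohexyl amide, compound 1, is the limit described in the limit of > 10000 nM in this assay, at which 1 of the 3 values shown sits, so the larger amide group has no number attached to it here. Compound 4 is expected to give 5000 nM, within 1500 nM to 20000 nM. The expected step of a 3.3-fold higher number from compound 3 to compound 4 (0.52 log units; beyond the scatter) therefore points toward weaker inhibition, with a fair chance that only a limit is returned.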

Compound 4, half-maximal inhibitory concentration: > 10000 nM
Compound 4 ended at the assay's limit; the forecaster's own chance of this, stated with the estimate: 35%; middle value at least 2.0-fold (0.30 log units) away from the limit.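

Compound 4 returns only a limit, so the 4,4-difluorocyclohexyl amide has no actual number in the compounds shown: the limit of > 10000 nM in this assay, at which 2 of the 4 values shown sit.

On the carbonyl carbon, 4,4-difluorocyclohexyl gives an at least 6.6-fold higher number from compound 3 to compound 4 (0.82 log units; beyond the scatter) and an at least 2.5-fold higher number from compound 2 to compound 4 (0.39 log units; beyond the scatter), placing it behind both cyclobutyl and 4-fluorophenyl in this assay. The chloro for fluoro step between compound 1 and compound 4 cannot be read.

Open, on these data alone, is how much of this loss belongs to ring size and how much to the two fluorines, which plain cyclohexyl would separate. Also open, as far as these compounds go, is whether cyclopropyl on the same carbonyl carbon would lower the number further.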